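Thioester replacing carbamate ester in the piperidine series

A few compounds are considered here, and "the series" means these few. Any claim that something is new, unique, unknown or untested is made for them only; others in the source may bear on it.

Measured so far, all in a functional assay on isolated protein for inhibition of Glucose-dependent insulinotropic receptor (Rattus norvegicus), read by HTRF and cAMP accumulation; a higher number here means a larger maximal response, a lower number a smaller maximal response:
Compound 1, `Cc1nc(S(C)(=O)=O)ccc1Oc1ncnc(OC2CCN(C(=O)OC(C)(C)CF)CC2)c1F`, gives 95%.
Compound 2, `Cc1nc(S(C)(=O)=O)ccc1Oc1ncnc(OC2CCN(C(=O)O[C@@H](C)C(F)(F)F)CC2)c1F`, gives 80%.
Compound 3, `Cc1nc(S(C)(=O)=O)ccc1Oc1ncnc(OC2CCN(C(=O)OC3(C(F)(F)F)COC3)CC2)c1F`, gives 84%.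

Compound 3 stands second highest of the three numbers. Its nearest neighbour is compound 2 (a number 4 percentage points higher from compound 2 to compound 3 (within the scatter)), a gap within the scatter, so no order between compound 2 and compound 3 is claimed. Its furthest is compound 1 (a number 11 percentage points lower from compound 1 to compound 3 (beyond the scatter)), beyond the scatter.

Compound 4 is `Cc1nc(S(C)(=O)=O)ccc1Oc1ncnc(OC2CCN(C(=O)SC(C)(C)C)CC2)c1F`. Relative to compound 3 the change is (tert-butyl)sulfanyl in place of (3-(trifluoromethyl)oxetan-3-yl)oxy on a carbonyl carbon.

Of the measured steps, only those on the oxygen next to the carbonyl group bear on this: a number 15 percentage points lower from compound 1 to compound 2 (beyond the scatter) and a number 11 percentage points lower from compound 1 to compound 3 (beyond the scatter), both modest and downward from compound 1, while a number 4 percentage points higher from compound 2 to compound 3 (within the scatter) is within the scatter. None of them replaces the oxygen itself by sulfur, so the step to compound 4 is not directly covered. All three measured values lie in a narrow band, and compound 4 is therefore expected to stay in that band, with a step of a number 1 percentage points higher from compound 3 to compound 4 (within the scatter), not beyond the scatter in either direction.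

The estimate for compound 4 in this assay is 85%, with a range from 70% to 98%.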

Compound 4, largest response reached (reported as efficacy), in percent of the reference or control that the assay uses: 76%
Compound 4: middle estimate off by 9 percentage points, on the high side, within the range that was stated.
By their numbers in this assay, from the lowest: compounds 4, 2 and 3 (each within the scatter of the next); then compound 1.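

Working notes on the carbonyl carbon: a sulfur-linked group without a ring, (tert-butyl)sulfanyl, gives a maximal response in this assay that cannot be separated from those of the two fluorinated oxy groups, with a number 8 percentage points lower from compound 3 to compound 4 (within the scatter) and a number 4 percentage points lower from compound 2 to compound 4 (within the scatter). The position therefore accepts sulfur in place of oxygen as the atom on the carbonyl carbon, together with loss of the fluorines and the oxetane ring, without a step beyond the scatter against these two compounds. Only the comparison with the fluoromethyl-bearing carbamate separates, with a number 19 percentage points lower from compound 1 to compound 4 (beyond the scatter), so compound 1 stays above all three others, each of its steps being printed as beyond the scatter, and no information at hand accounts for these differences.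

Since the linking atom and the alkyl group change together in every step to compound 4, the share of sulfur in the result stays unresolved, and a tert-butoxy group on the same carbonyl carbon would be the direct counterpart for separating the two. Going by these compounds, whether an amine on this carbonyl carbon, or a (1-fluoro-2-methylpropan-2-yl)sulfanyl group, would hold the response in this assay also remains open.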